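Ethoxy in place of methoxy on the anilide ring

The source may hold more compounds than are shown below. What is called first, only, known or untested is meant among the compounds shown, and "the series" means these compounds.

Compound 1 `O=C(Nc1ccc(F)cc1)c1c(NCCO)cc(-c2cccc(Br)c2)oc1=O` and compound 2 `COc1ccccc1NC(=O)c1c(NCCO)cc(-c2cccc(Br)c2)oc1=O` share one core. In an ADME assay on Huh-7 cells (Homo sapiens) for cytotoxicity, with a stated time of 3 days (a lower number here means that less compound is tolerated, a higher number that more compound is tolerated), compound 1 sits at a limit, > 20000 nM. In this assay compound 2 likewise sits at a limit, > 20000 nM. The step that the two limits leave unreadable from compound 1 to compound 2 is therefore unreadable, since both values rest at the limit of > 20000 nM in this assay, at which 2 of the 2 values shown sit. Compound 3 `CCOc1ccccc1NC(=O)c1c(NCCO)cc(-c2cccc(Br)c2)oc1=O` carries methyl in place of hydrogen on a saturated chain carbon bound to an oxygen on an aromatic ring. Going by the values given here, no measured step bears on this change, and the only known step gives no size, so the expected step that the limit leaves unreadable from compound 2 to compound 3 is none beyond the scatter. Compound 3 is estimated at 30000 nM, between 15000 nM and 80000 nM, most likely again reported as a limit.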

Compound 3, half-maximal cytotoxic concentration: > 20000 nM
Compound 3: a limit, no number; the forecaster's own chance of this, stated with the estimate: 85%; the middle value lies beyond the limit too.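

Compound 3 adds no readable step against compound 1 or compound 2 in this assay, since each value is only a limit: the limit of > 20000 nM in this assay, at which 3 of the 3 values shown sit. The compounds shown leave open how far apart their true half-maximal cytotoxic concentrations lie, including whether 2-ethoxyphenyl differs from 2-methoxyphenyl.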